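Vinyl for methyl on the pendant phenyl ring

The source may report more compounds than this note shows. Statements on the series, on what has been measured and on what is new or still open speak of the compounds shown alone.

Compound 1 `COc1cc(-c2ccnc3cc(-c4ccc(C)cc4)nn23)cc(OC)c1OC` is the lower of the two numbers measured in a functional assay on MCF7 cells (Homo sapiens) for inhibition, read by CCK-8 assay, with a stated time of 48 h; a lower number here means a stronger inhibitor, a higher number a weaker inhibitor; in this assay compound 1 gives 47 nM. Going by the values given here, compound 2 `COc1ccc(-c2cc3nccc(-c4cc(OC)c(OC)c(OC)c4)n3n2)cc1` gives 125 nM in this assay, and the single measured step, a 2.7-fold higher number from compound 1 to compound 2 (0.42 log units; beyond the scatter), comes from a methoxy in place of methyl on an aromatic carbon. Compound 3 `C=Cc1ccc(-c2cc3nccc(-c4cc(OC)c(OC)c(OC)c4)n3n2)cc1` has not been measured in this assay. The change from compound 1 to compound 3 is vinyl in place of methyl on an aromatic carbon. It sits at the same place as the change from compound 1 to compound 2, so that step is the only one that bears on it, and it was modest. Among the compounds with values here, a vinyl group is not a methoxy, so no direct precedent exists; a small step in this assay, most likely toward a somewhat higher number, is expected. For compound 3 the estimated value in this assay is 65 nM, within 25 nM to 170 nM, corresponding to an expected step of a 1.4-fold higher number from compound 1 to compound 3 (0.14 log units; within the scatter).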

Compound 3, half-maximal inhibitory concentration: 193 nM
Compound 3: middle estimate off by 3.0-fold (0.47 log units), on the low side; measured number outside the range, above it.
By their numbers in this assay, from the lowest: compound 1; then compounds 2 and 3 (each within the scatter of the next).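

In this assay the change from 4-methylphenyl to 4-vinylphenyl gives a 4.1-fold higher number from compound 1 to compound 3 (0.61 log units; beyond the scatter) and is the second replacement of methyl on this aromatic carbon, para to a large group, to end above compound 1. The two replacements are not separated here, with vinyl in place of methoxy giving a 1.5-fold higher number from compound 2 to compound 3 (0.19 log units; within the scatter) and so leaving compound 2 and compound 3 at one level. Among the three compounds, methyl holds the lowest number at this place, and no measurement on these compounds accounts for that.

Open, going by these compounds, is whether ethyl, the saturated counterpart of vinyl, behaves like methyl or like vinyl at this place. Open too, on these data alone, is whether chlorine, an amine or a longer chain such as propyl could match or go below the number of compound 1.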